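The source may report more compounds than this note shows. Statements on the series, on what has been measured and on what is new or still open speak of the compounds shown alone.

Compound 1 `COc1ccc(S(=O)(=O)NCCN2CCC(CCC(=O)c3cc(Cl)c(N)cc3OC)CC2)cc1` and compound 2 `COc1cc(N)c(Cl)cc1C(=O)CCC1CCN(CCNS(=O)(=O)c2ccc(OC)c(N3CCN(C)CC3)c2)CC1` share one core and differ only in that compound 2 carries 4-methylpiperazin-1-yl in place of hydrogen on an aromatic carbon. In an assay on HEK293 cells for displacement of a labelled ligand from 5-hydroxytryptamine receptor 6 (Homo sapiens), with a stated time of 60 min, tested at 1 uM, in the presence of a further agent that is not named here (a higher number here means a stronger effect of the compound at the concentration tested, a lower number a weaker effect), compound 1 gives 52%, while compound 2 gives 43%. Among the measured compounds shown here, the only measured step, a number 9 percentage points lower from compound 1 to compound 2 (within the scatter), therefore stays within the scatter, and the two numbers cannot be ranked against each other. Compound 3 `COc1cc(N)c(Cl)cc1C(=O)CCC1CCN(CCNS(=O)(=O)c2ccc(N)cc2)CC1` differs from compound 1 by amino in place of methoxy on an aromatic carbon, read one bond further out as (4-methoxyphenyl)sulfonyl to (4-aminophenyl)sulfonyl. For the measured compounds named here, no measured pair swaps these two groups, so the step from compound 1 to compound 2 bears on it only loosely: it shows that one change on that sulfonyl-bearing part of the molecule left the reading within the scatter. On that basis a step of a number 5 percentage points lower from compound 1 to compound 3 (within the scatter) is expected in this assay, with no move beyond the scatter foreseen. Compound 3 is estimated at 47%, in a range from 27% to 67%.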

Compound 3, a percentage reported as inhibition, at one concentration (the size of the read-out at that concentration, not a potency): 46%
Compound 3: the middle estimate sits 1 percentage points above what was measured, and the stated range covers the measured number.
By their numbers in this assay, from the lowest: compounds 2, 3 and 1 (each within the scatter of the next).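

Putting amino in place of methoxy on the aromatic carbon para to a large group gives a number 6 percentage points lower from compound 1 to compound 3 (within the scatter) in this assay. The earlier pair covered only the addition of 4-methylpiperazin-1-yl to this ring, whereas this pair replaces the group at the para position itself, and here too the reading stays within the scatter, even though amino brings a hydrogen-bond donor and methoxy brings none. Nothing available here explains why the reading holds across this change.

On these data alone, whether the same holds for other groups at this position, such as a hydroxyl, a fluorine atom, a carboxylic acid or a longer alkoxy chain, remains open. Also open, as far as these compounds go, is whether the two compounds would still read alike across a range of concentrations, since a reading at a single concentration is not a potency.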